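Extending the Amide Substituent Where Every Value Is a Limit

This account rests on a few compounds, and the source may have more. Where it says the series, first, only, none or still open, it means among the compounds named here.

Compound 1 `O=C(c1cnc(NC(=O)C2CCCCC2)s1)c1cccc2ccccc12` was examined in an ADME assay on P388D1 cells (Mus musculus) for cytotoxicity, read by fluorescence and resazurin assay, with a stated time of 72 h; a higher number here means a weaker inhibitor, a lower number a stronger inhibitor; there compound 1 reaches only the limit of > 40000 nM, so no number is known for it. Compound 3 `O=C(CCC1CCCCC1)Nc1ncc(C(=O)c2cccc3ccccc23)s1` likewise returns only the limit of > 40000 nM in this assay. The step that the two limits leave unreadable from compound 1 to compound 3 is therefore unreadable; the change made is 2-cyclohexylethyl in place of cyclohexyl on a carbonyl carbon. Compound 2 `O=C(Nc1ncc(Cc2cccc3ccccc23)s1)C1CCCCC1` also gives only the limit of > 40000 nM in this assay. How compound 2 differs from compound 1 is not broken down here. Compound 4 `O=C(CCC1CCCCC1)Nc1ncc(Cc2cccc3ccccc23)s1`, not yet measured, carries the same change relative to compound 2, (2-cyclohexylethyl in place of cyclohexyl on a carbonyl carbon), at a place described in identical words. All three values sit at the limit (the limit of > 40000 nM in this assay, at which 3 of the 3 values shown sit), so the earlier step offers no direction. Compound 4 is expected to stay at that limit too, an estimated step that the limit leaves unreadable from compound 2 to compound 4. Compound 4 is estimated at 60000 nM.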

Compound 4, half-maximal inhibitory concentration: 27600 nM
Compound 4: middle estimate off by 2.2-fold (0.34 log units), on the high side, and the stated range ends above it.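

In this assay, 2-cyclohexylethyl in place of cyclohexyl on a carbonyl carbon gives an at least 1.4-fold lower number from compound 2 to compound 4 (0.16 log units; that floor lies within the scatter) on the core of compound 2. Compound 2 is recorded only as a limit and the floor of this step lies within the scatter, so the step shows neither a real change nor its true size. Whether the change carries from one core to the other stays unshown, because the step from compound 1 to compound 3 cannot be read: the limit of > 40000 nM in this assay, at which 3 of the 4 values shown sit.

The compounds shown leave open how a longer chain would read in this assay on either core. They also leave open how an amine or a carboxylic acid in place of the 2-cyclohexylethyl group would read there.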